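The source may hold more compounds than are shown below. What is called first, only, known or untested is meant among the compounds shown, and "the series" means these compounds.

Among the measured compounds shown here, in an ADME assay on THP-1 cells (Homo sapiens) for cytotoxicity, read by flow cytometry and propidium iodide staining, with a stated time of 72 h (a lower number here means a stronger inhibitor, a higher number a weaker inhibitor), compound 2 (`COc1cccc(-c2oc3ccc(NC(C)=O)cc3c(=O)c2OC)c1`) gives 5000 nM, the lowest of the two numbers so far, set against compound 1 (`COc1ccccc1-c1oc2ccc(NC(C)=O)cc2c(=O)c1OC`) at 108000 nM. Compound 3 (`COc1ccc(-c2oc3ccc(NC(C)=O)cc3c(=O)c2OC)cc1`) carries one structural change: 4-methoxyphenyl in place of 3-methoxyphenyl on an aromatic carbon. For the measured compounds named here, only one measured step bears on it, a 22-fold lower number from compound 1 to compound 2 (1.33 log units; beyond the scatter), a large change beyond the scatter, made when 3-methoxyphenyl replaced 2-methoxyphenyl. That single step shows that the methoxy position can matter, but it sets no direction for this further move. No step beyond the scatter is therefore expected, and the estimated step is a 1.2-fold higher number from compound 2 to compound 3 (0.08 log units; within the scatter). Compound 3 is estimated at 6000 nM, with an expected range of 1500 nM to 30000 nM.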

Compound 3, half-maximal inhibitory concentration: > 50000 nM
Compound 3 ended at the assay's limit; the forecaster's own chance of this, stated with the estimate: 10%; middle value at least 8.3-fold (0.92 log units) away from the limit.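

Replacing 3-methoxyphenyl with 4-methoxyphenyl in this assay gives an at least 10-fold higher number from compound 2 to compound 3 (1.00 log units; beyond the scatter). Compound 3 stands at > 50000 nM, which is a limit of the assay and not a number. Both changes of methoxy position away from 3-methoxyphenyl now raise the number beyond the scatter, leaving compound 2 with the lowest value of the three.

The step from compound 1 to compound 3 cannot be read. On these data alone, whether an amine or a carboxylic acid in place of the methoxy group of 3-methoxyphenyl would keep the number low remains open.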